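The source may hold more compounds than are shown below. What is called first, only, known or untested is meant among the compounds shown, and "the series" means these compounds.

In an ADME assay on microsomes from liver (Rattus norvegicus) for metabolic stability, with a stated time of 10 min, tested at 0.5 uM (a higher number here means that more of the compound is left, a lower number that less of the compound is left), compound 1 (`CC(C)COc1ncc(-c2cn(C)c3cc(C(=O)NS(C)(=O)=O)ccc23)cc1Cl`) gives 66% and stands lowest of the three measured compounds. Compound 3 (`Cn1cc(-c2ccc(C(F)(F)F)cc2)c2ccc(C(=O)NS(=O)(=O)C3CC3)cc21`) with 92% is nearest and compound 2 (`Cn1nc(-c2ccc(C(F)(F)F)cc2)c2cc(F)c(C(=O)NS(=O)(=O)C3CC3)cc21`) with 100% is furthest, both gaps lying beyond the usual scatter. Compound 4 (`CC(C)COc1ncc(-c2cn(C)c3cc(C(=O)NS(C)(=O)=O)c(F)cc23)cc1Cl`) is still unmeasured and differs from compound 1 by fluoro in place of hydrogen on an aromatic carbon in one place: fluoro in place of hydrogen on an aromatic carbon, ortho to a (methylsulfonyl)carbamoyl group. For the measured compounds named here, no measured pair shows this change alone, so only a small rise in this assay is expected, within the scatter. The estimate amounts to a number 4 percentage points higher from compound 1 to compound 4 (within the scatter) overall. Compound 4 is estimated at 70% within a range of 55% to 84% for the percent of compound remaining.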

Compound 4, percent of the compound remaining: 85%
Beside the measured number, compound 4's estimate is 15 percentage points below it; measured number above the stated range.
By their numbers in this assay, from the lowest: compound 1; then compounds 4, 3 and 2 (each within the scatter of the next, the first and the last beyond it).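

In this assay, fluoro in place of hydrogen on this aromatic carbon, ortho to the (methylsulfonyl)carbamoyl group, gives a number 19 percentage points higher from compound 1 to compound 4 (beyond the scatter). For the compounds shown here, this is the only reading of the change at this position, and it shows that one entering heavy atom here can move the percent of compound remaining beyond the usual scatter. Nothing among the available data accounts for the step.

The finding rests on this single pair. From the compounds shown here alone, whether a chlorine atom or a methoxy group on the same carbon would give a similar step stays open, as does whether fluoro here would do the same on another core.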